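Three Aryl Variants at the Assay Limit, a Fourth Awaited

The compounds below may be only part of what the source reports. "The series", "measured", "known", "first", "only" and "open" are said of these compounds alone.

Three compounds sharing one core were tested in a functional assay on A549 cells (Homo sapiens) for inhibition, read by MTT assay, with a stated time of 24 h; on this read-out lower numbers stand for stronger inhibition and higher numbers for weaker inhibition. Compound 1 `CCOC(=O)C1=Cc2ccccc2OC1(OCc1cc(-c2ccc(OC)cc2)no1)C(F)(F)F` carries a 4-methoxyphenyl group, compound 2 `CCOC(=O)C1=Cc2ccccc2OC1(OCc1cc(-c2ccc(Br)cc2)no1)C(F)(F)F` a 4-bromophenyl group, and compound 3 `CCOC(=O)C1=Cc2ccccc2OC1(OCc1cc(-c2ccc([N+](=O)[O-])cc2)no1)C(F)(F)F` a 4-nitrophenyl group. In this assay compound 1 gives only a limit, > 150000 nM. Compound 2 likewise gives only a limit, > 150000 nM. Compound 3 too gives only a limit, > 150000 nM. Because of the limit of > 150000 nM in this assay, at which 3 of the 3 values shown sit, the three steps between them are unreadable: a step that the two limits leave unreadable from compound 1 to compound 2, a step that the two limits leave unreadable from compound 1 to compound 3 and a step that the two limits leave unreadable from compound 2 to compound 3. Compound 3 therefore stands where every measured compound stands, at the limit, with no number to rank it.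

Compound 4 `CCOC(=O)C1=Cc2ccccc2OC1(OCc1cc(-c2cccc(C(F)(F)F)c2)no1)C(F)(F)F` is not yet measured. It differs from compound 3 by 3-(trifluoromethyl)phenyl in place of 4-nitrophenyl on an aromatic carbon. Within the data shown here, none of the measured steps shows a readable size, so no step beyond the scatter can be expected in this assay from this change. The step from compound 3 to compound 4 is estimated as a step that the limit leaves unreadable from compound 3 to compound 4. Compound 4 is expected to give about 200000 nM, within 50000 nM to 1000000 nM, most likely again as a limit.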

Compound 4, half-maximal inhibitory concentration: 48600 nM
Compound 4: the middle estimate sits 4.1-fold (0.61 log units) above what was measured; the measured number lies below the stated range.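

In this assay, the aryl position on the five-membered aromatic ring now responds to a change of group, and 3-(trifluoromethyl)phenyl is the only group of the four shown that gives a number rather than a limit. Against the other three groups it gives an at least 3.0-fold lower number from compound 3 to compound 4 (0.48 log units; beyond the scatter), an at least 3.0-fold lower number from compound 2 to compound 4 (0.48 log units; beyond the scatter) and an at least 3.0-fold lower number from compound 1 to compound 4 (0.48 log units; beyond the scatter). These sizes are minimums, and the steps among compound 1, compound 2 and compound 3 still cannot be read, because of one limit: the limit of > 150000 nM in this assay, at which 3 of the 4 values shown sit.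

The compounds shown leave open whether the change rests on the trifluoromethyl group itself or on where it sits on the phenyl ring. They also leave open whether a nitrile or an amine on that phenyl ring would give a number in this assay.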